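This account rests on a few compounds, and the source may have more. Where it says the series, first, only, none or still open, it means among the compounds named here.

In a functional assay on HFF cells (Homo sapiens) for inhibition (a higher number here means a weaker inhibitor, a lower number a stronger inhibitor), compound 1, `Cc1nsc2c1nc(SCc1ccccc1)n2[C@H]1C[C@H](O)[C@@H](CO)O1`, gives only a limit of the assay, > 100000 nM. Compound 2, `CSc1nc2c(C)nsc2n1[C@@H]1O[C@H](CO)[C@@H](O)[C@H]1O`, likewise gives only a limit in this assay, > 100000 nM. Where compound 2 stands is thus known only as a bound: it sits at the limit of > 100000 nM in this assay, at which 2 of the 2 values shown sit, together with the other value shown. Compound 3, `Cc1nsc2c1nc(SCc1ccccc1)n2[C@@H]1O[C@H](CO)[C@@H](O)[C@H]1O`, has not yet been measured in this assay. It differs from compound 2 in a single place: phenyl in place of hydrogen on a saturated chain carbon bound to a sulfur. Among the measured compounds shown here, no pair of measured compounds is available that would show how this change, on its own, moves the read-out. Because compound 2 shows only a limit at the limit of > 100000 nM in this assay, at which 2 of the 2 values shown sit, the expected step that the limit leaves unreadable from compound 2 to compound 3 is taken as nothing beyond the scatter, and another limit rather than a number is the likelier outcome. Compound 3 is therefore estimated at 150000 nM, with a range from 30000 nM to 1000000 nM.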

Compound 3, half-maximal inhibitory concentration: > 100000 nM
Compound 3 ended at the assay's limit; the forecaster's own chance of this, stated with the estimate: 85%; the middle value does not contradict the limit.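

Compound 1, compound 2 and compound 3 give no readable step, as each stands only at a limit and not at a number: the limit of > 100000 nM in this assay, at which 3 of the 3 values shown sit.

The compounds shown leave open whether changing methylsulfanyl to benzylsulfanyl, or adding hydroxy on a saturated ring carbon, moves the read-out in this assay at all.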